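The compounds below may be only part of what the source reports. "The series", "measured", "known", "first", "only" and "open" are said of these compounds alone.

Measured so far in a functional assay on SW-620 cells (Homo sapiens) for antiproliferative activity, read by MTT assay, with a stated time of 3 days; on this read-out lower numbers stand for stronger inhibition and higher numbers for weaker inhibition:
compound 1 `CCCCCCCCC#Cc1cn(C/C=C\CN2C(=O)c3ccccc3C2=O)c(=O)[nH]c1=O` — 67000 nM
compound 2 `O=C1c2ccccc2C(=O)N1C/C=C\Cn1cc(C#Cc2ccc(Br)cc2)c(=O)[nH]c1=O` — > 100000 nM, which is a limit of this assay
compound 3 `CCCCCCCCC#Cc1cn(C/C=C/CN2C(=O)c3ccccc3C2=O)c(=O)[nH]c1=O` — 87000 nM

Compound 3 gives the larger of the two numbers, but with a 1.3-fold higher number from compound 1 to compound 3 (0.11 log units; within the scatter) the two cannot be told apart; that step rests only on (the fact that compounds 1 and 3 differ only in the configuration as drawn). Compound 4 `CCCCCc1ccc(C#Cc2cn(C/C=C/CN3C(=O)c4ccccc4C3=O)c(=O)[nH]c2=O)cc1` carries 4-pentylphenyl in place of octyl on a triple-bonded carbon. Going by the values given here, the one measured step that bears on this change is the replacement of octyl by an aryl group: an at least 1.4-fold higher number from compound 1 to compound 2 (0.17 log units; that floor lies within the scatter), where the end point is set by the limit of > 100000 nM in this assay, at which 1 of the 3 values shown sits, so the true size of that step is unknown and may be larger. Moving from octyl to 4-pentylphenyl is expected to behave in the same sense, a step upward or none beyond the scatter, with a real chance that only a limit is returned. Compound 4 is therefore expected to give about 120000 nM, in the range 50000 nM to 300000 nM, which would mean an expected step of a 1.4-fold higher number from compound 3 to compound 4 (0.14 log units; within the scatter).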

Compound 4, half-maximal inhibitory concentration: 30000 nM
Estimate against measurement, compound 4: 4.0-fold (0.60 log units) above; measured number outside the range, below it.
By their numbers in this assay, from the lowest: compound 4; then compounds 1 and 3 (each within the scatter of the next). At a limit, above all of these: compound 2.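

In this assay, going by these compounds alone, 4-pentylphenyl in place of octyl on a triple-bonded carbon gives a 2.9-fold lower number from compound 3 to compound 4 (0.46 log units; beyond the scatter) and is the only step printed as beyond the scatter. This place therefore accepts an aryl group with a lower number, and compound 4 goes against the upward sense suggested by the step to 4-bromophenyl, whose size stays unread: the limit of > 100000 nM in this assay, at which 1 of the 4 values shown sits. For compound 2 the reading > 100000 nM is a limit.

As far as these compounds go, whether the lower number of compound 4 follows from the aromatic ring, from the pentyl chain on it or from both stays open, and compounds 2 and 4 differ in more than one place, so they give no direct comparison. Also open, from the compounds shown here alone, are a longer chain in place of octyl, an amine or a carboxylic acid on the phenyl ring, and whether double-bond configuration matters among the aryl compounds.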